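The source may report more compounds than this note shows. Statements on the series, on what has been measured and on what is new or still open speak of the compounds shown alone.

Measured in a functional assay on MCF7 cells (Homo sapiens) for inhibition, read by MTT assay, with a stated time of 72 h; a higher number here means a weaker inhibitor, a lower number a stronger inhibitor:
Compound 1 `Oc1ccc(-c2nnc(SCCCN3CCN(c4nc5ccccc5o4)CC3)o2)cc1`: 260000 nM
Compound 2 `Clc1ccc(-c2nnc(SCCCN3CCN(c4nc5ccccc5s4)CC3)o2)cc1`: 116000 nM

Of these two, compound 2 has the lower number, at 116000 nM, and the gap to compound 1 lies beyond the usual scatter. Compound 3 `Oc1ccc(-c2nnc(SCCCN3CCN(c4nc5ccccc5s4)CC3)o2)cc1` departs from compound 2 in one place, with hydroxy in place of chloro on an aromatic carbon, so that 4-chlorophenyl becomes 4-hydroxyphenyl (hydroxy in place of chloro on an aromatic carbon). Within the data shown here, no measured pair shows this change alone, so its size in this assay cannot be read directly from the data. A small move toward a higher number is expected, possibly none beyond the scatter. Among the measured compounds shown here, the only other number available is that of compound 1 at 260000 nM, and the expectation stays on the side of that value. The estimated step is a 1.4-fold higher number from compound 2 to compound 3 (0.14 log units; within the scatter). The expected value for compound 3 is 160000 nM, with an estimated range from 70000 nM to 350000 nM.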

Compound 3, half-maximal inhibitory concentration: 81900 nM
The estimate for compound 3 lay 2.0-fold (0.29 log units) above the measured number; measured number inside the range.
By their numbers in this assay, from the lowest: compounds 3 and 2 (each within the scatter of the next); then compound 1.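

In this assay, replacing chloro with hydroxy on the aromatic carbon gives a 1.4-fold lower number from compound 2 to compound 3 (0.15 log units; within the scatter), so with 1,3-benzothiazol-2-yl held constant, the two groups cannot be told apart at this position. Compound 1 and compound 2 differed in two places and could not separate their effects, but the new compound isolates one of them: with 4-hydroxyphenyl held constant, 1,3-benzothiazol-2-yl in place of 1,3-benzoxazol-2-yl on an amine nitrogen in a ring gives a 3.2-fold lower number from compound 1 to compound 3 (0.50 log units; beyond the scatter). No available evidence bears on either step.

Going by these compounds, it remains open whether methoxy, an amine or a carboxylic acid at this position would also stay within the scatter of chloro and hydroxy. Also open, on these data alone, is whether the step from 1,3-benzoxazol-2-yl to 1,3-benzothiazol-2-yl would keep its size with 4-chlorophenyl in place of 4-hydroxyphenyl.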